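Methyl on the thiophene of a sulfonamide endothelin ligand

This account rests on a few compounds, and the source may have more. Where it says the series, first, only, none or still open, it means among the compounds named here.

Among the compounds with values here, in an assay on cells (Endothelial cell) for binding affinity to Endothelin-1 receptor (Sus scrofa) (a higher number here means a weaker inhibitor, a lower number a stronger inhibitor), compound 2 `CSc1cnc(OCCOc2ncnc(NS(=O)(=O)c3ccc(C(C)(C)C)cc3)c2-c2cccs2)nc1` gives 0.89 nM, the only number recorded. Compound 1 `COc1ccc(-c2c(NS(=O)(=O)c3ccc(C(C)(C)C)cc3)ncnc2OCCOc2ncc(SC)cn2)cc1` sits at a limit of this assay, < 0.001 nM, and no exact number is known for it. Within the data shown here, the one measured step, an at least 890-fold higher number from compound 1 to compound 2 (2.94 log units; beyond the scatter), is the only comparison available; it concerns an exchange of one aryl ring for another rather than a substituent on a ring, and its size rests on (the limit of < 0.001 nM in this assay, at which 1 of the 2 values shown sits), so the true gap may be wider than stated.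

Compound 3 `CSc1cnc(OCCOc2ncnc(NS(=O)(=O)c3ccc(C(C)(C)C)cc3)c2-c2ccc(C)s2)nc1` differs from compound 2 by methyl in place of hydrogen on an aromatic carbon. Among the measured compounds shown here, no measured step alters a substituent on the thiophen-2-yl group, so the aryl exchange offers little guidance on this change. A methyl on a five-membered aromatic ring is a modest alteration, and without a matching precedent no step beyond the scatter is expected in this assay. The estimate for compound 3 is 0.6 nM, with a range from 0.15 nM to 2.5 nM, which as a step means a 1.5-fold lower number from compound 2 to compound 3 (0.17 log units; within the scatter) is expected.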

Compound 3, half-maximal inhibitory concentration: 0.16 nM
Compound 3: middle estimate off by 3.8-fold (0.57 log units), on the high side; the measured number falls inside the stated range.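

Substitution on the thiophene is not neutral in this assay: methyl on the aromatic carbon next to the ring sulfur, which turns thiophen-2-yl into 5-methylthiophen-2-yl, gives a 5.6-fold lower number from compound 2 to compound 3 (0.75 log units; beyond the scatter). Within the data shown here, this is the first change made on the thiophene itself, and a single added carbon at this place already moves the number beyond the scatter. The 4-methoxyphenyl ring of compound 1 still separates from the methylated thiophene by an at least 160-fold higher number from compound 1 to compound 3 (2.20 log units; beyond the scatter), and that gap is a bound rather than a measured size, as the value for compound 1 is a limit: the limit of < 0.001 nM in this assay, at which 1 of the 3 values shown sits.

On these data alone, what a chlorine, an ethyl or a methoxy group on this same carbon would do remains open, so the two compounds with a thiophene cannot yet say whether the gain is particular to methyl. Also open, as far as these compounds go, is whether methyl on another carbon of the thiophene gives a step of similar size, and how much further a 5-methoxythiophen-2-yl group would close the distance to compound 1.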